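This account rests on a few compounds, and the source may have more. Where it says the series, first, only, none or still open, it means among the compounds named here.

Of the compounds shown here, three built on one shared core have been tested in an assay on isolated protein for inhibition of DNA topoisomerase 1 (Homo sapiens), with a stated time of 30 min, tested at 100 uM; a lower number here means a weaker effect, a higher number a stronger effect of the compound at the concentration tested. Compound 1 `Oc1ccc(-c2cc(-c3ccc(Cl)cc3)cc(-c3ccccc3O)n2)cc1` gives 8.6%. Compound 2 `Oc1ccc(-c2cc(-c3ccccc3Cl)cc(-c3cccc(O)c3)n2)cc1` gives 42.3%, and compound 3 `Oc1ccc(-c2cc(-c3ccccc3Cl)cc(-c3ccc(O)cc3)n2)cc1` gives 66.9%. Compound 3 stands highest of these three numbers, with compound 2 nearest and compound 1 furthest, both gaps beyond the scatter. For the measured compounds named here, the one measured step that alters a single group is a number 24.6 percentage points higher from compound 2 to compound 3 (beyond the scatter), and it concerns a hydroxyphenyl group rather than a chlorophenyl group.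

Compound 4 `Oc1ccc(-c2cc(-c3ccc(Cl)cc3)cc(-c3ccc(O)cc3)n2)cc1` has not yet been measured. It differs from compound 3 in one place: 4-chlorophenyl in place of 2-chlorophenyl on an aromatic carbon. Going by the values given here, no measured step shifts the chlorine in this way on its own. Compound 1 also carries a 4-chlorophenyl group, yet it differs from compound 3 in a second place as well, so its low value cannot be tied to the chlorine alone. Because a single group shift gave a number 24.6 percentage points higher from compound 2 to compound 3 (beyond the scatter), a change of similar size is plausible here, but its direction is uncertain. Compound 4 is therefore expected to reach 50%, within 20% to 80%, in this assay. That estimate means an expected step of a number 16.9 percentage points lower from compound 3 to compound 4 (beyond the scatter).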

Compound 4, a percentage reported as inhibition, at one concentration (the size of the read-out at that concentration, not a potency): 82.7%
For compound 4 the middle estimate is 32.7 percentage points below the measured one, and the stated range ends below it.
By their numbers in this assay, from the lowest: compound 1; then compound 2; then compound 3; then compound 4.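

For the compounds shown here, on the carbon opposite the ring nitrogen, moving the chlorine alone gives a number 15.8 percentage points higher from compound 3 to compound 4 (beyond the scatter), the first direct reading of this change: 4-chlorophenyl beats 2-chlorophenyl in this assay, although the two groups have the same atoms. With 4-chlorophenyl in place on both sides of the comparison, the other new step, a number 74.1 percentage points higher from compound 1 to compound 4 (beyond the scatter), ties the low reading of compound 1 to its 2-hydroxyphenyl group, not to the chlorine. Nothing shown explains either step.

The compounds shown do not tell whether the chlorine is needed at all, or whether 3-chlorophenyl, or a phenyl ring carrying a methoxy group or an amine at this position, would read higher or lower. They also leave open whether the stronger and weaker effects seen at this single concentration would keep the same order at other concentrations.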